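Aryl replacement at the chain carbon and tissue distribution

The source may report more compounds than this note shows. Statements on the series, on what has been measured and on what is new or still open speak of the compounds shown alone.

Compound 2 `O=C(O)CC(Cc1nc(CCCc2ccc3c(n2)NCCC3)no1)c1cnc(C2CC2)s1` was examined in an in vivo ADME assay on the whole organism for pharmacokinetics, with Rattus norvegicus as the target, at a dose of 5 mg/kg by the intravenous route (on this read-out lower numbers stand for narrower distribution and higher numbers for wider distribution into tissues), where compound 2 gives 0.497 L/kg. Among the two numbers measured so far this is the lowest; its nearest neighbour is compound 1 `COc1ccc(C(CC(=O)O)Cc2nc(CCCc3ccc4c(n3)NCCC4)no2)cn1`, which in this assay gives 0.694 L/kg. Going by the values given here, the single step between them, a 1.4-fold lower number from compound 1 to compound 2 (0.15 log units; within the scatter), is therefore the only guide available. Compound 3 `O=C(O)CC(Cc1nc(CCCc2ccc3c(n2)NCCC3)no1)c1ccc2c(c1)OCC2` differs from compound 2 by a group of 9 heavy atoms (8 carbon, 1 oxygen; one five-membered non-aromatic ring with 1 hetero atom, one six-membered aromatic ring of carbon only) in place of a group of 8 heavy atoms (6 carbon, 1 nitrogen, 1 sulfur; one three-membered non-aromatic ring of carbon only, one five-membered aromatic ring with 2 hetero atoms), on a saturated chain carbon bound to two saturated chain carbons. Among the compounds with values here, the one step that bears on this change, the exchange of one aryl group for another at the same saturated chain carbon, stayed within the scatter, so a shift beyond the scatter in this assay is not expected for compound 3. The expected step is a 1.2-fold higher number from compound 2 to compound 3 (0.08 log units; within the scatter), with compound 3 estimated at 0.6 L/kg and a range from 0.35 L/kg to 1.1 L/kg.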

Compound 3, volume of distribution at steady state: 0.803 L/kg
Beside the measured number, compound 3's estimate is 1.3-fold (0.13 log units) below it; the range from low to high includes it.
By their numbers in this assay, from the lowest: compounds 2, 1 and 3 (each within the scatter of the next).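

In this assay, the new group brings a six-membered aromatic ring of carbon only and a five-membered non-aromatic ring with 1 hetero atom, a ring type that neither earlier compound carried at this saturated chain carbon. The exchange still gives a 1.6-fold higher number from compound 2 to compound 3 (0.21 log units; within the scatter) and a 1.2-fold higher number from compound 1 to compound 3 (0.06 log units; within the scatter), so across these three compounds no aryl exchange at this place moves the number beyond the scatter, even with the aromatic ring holding no hetero atom. Nothing shown accounts for the differences among the three numbers.

The compounds shown leave open whether a group without an aromatic ring, such as isopropyl or a dimethylamino group, would keep the number within the scatter at this place. They also leave open whether a plain hydrogen there would do so.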